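The compounds below may be only part of what the source reports. "The series", "measured", "known", "first", "only" and "open" are said of these compounds alone.

Measured compounds in a functional assay on HT-29 cells (Homo sapiens) for antiproliferative activity, read by MTT assay, with a stated time of 72 h; on this read-out lower numbers stand for stronger inhibition and higher numbers for weaker inhibition:
compound 1 `CN(C)CCn1cnnc1-c1cc(Oc2ccc(NC(=O)Nc3ccc(Cl)c(C(F)(F)F)c3)cc2F)ccn1`, 880 nM
compound 2 `CN(C)CCn1cnnc1-c1cc(Oc2ccc(NC(=O)Nc3cccc(C(F)(F)F)c3)cc2F)ccn1`, 1470 nM
compound 3 `CN(C)CCn1cnnc1-c1cc(Oc2ccc(NC(=O)Nc3ccc(F)c(Cl)c3)cc2F)ccn1`, 720 nM

Among these three numbers, compound 1 stands second highest; its nearest neighbour is compound 3, with a 1.2-fold lower number from compound 1 to compound 3 (0.09 log units; within the scatter), and its furthest is compound 2, with a 1.7-fold higher number from compound 1 to compound 2 (0.22 log units; within the scatter). Compound 4 `CN(C)CCCn1cnnc1-c1cc(Oc2ccc(NC(=O)Nc3ccc(Cl)c(C(F)(F)F)c3)cc2F)ccn1` has not yet been measured. It differs from compound 1 only on the chain carried by the triazole: (dimethylamino)methyl in place of dimethylamino on a saturated chain carbon, two bonds along the chain from an aromatic nitrogen. All three measured steps change the aryl group on the urea nitrogen and leave this chain untouched; between compound 2 and compound 3 the change is a 2.0-fold lower number from compound 2 to compound 3 (0.31 log units; beyond the scatter), and the other two steps are within the scatter. Going by the values given here, no measured step therefore bears on the change from compound 1 to compound 4, and the data give no ground for expecting movement in either direction. Compound 4 is estimated at 900 nM, with a range from 400 nM to 2000 nM. The step this estimate means is a 1.0-fold higher number from compound 1 to compound 4 (0.01 log units; within the scatter), an expectation of no change beyond the scatter.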

Compound 4, half-maximal inhibitory concentration: 1400 nM
Compound 4: middle estimate off by 1.6-fold (0.19 log units), on the low side, and the stated range covers the measured number.
By their numbers in this assay, from the lowest: compounds 3, 1, 4 and 2 (each within the scatter of the next, the first and the last beyond it).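

In this assay, going by these compounds alone, replacing 2-(dimethylamino)ethyl with 3-(dimethylamino)propyl gives a 1.6-fold higher number from compound 1 to compound 4 (0.20 log units; within the scatter), the first reading on this chain, as every earlier step changed the aryl group on the urea nitrogen. With the 4-chloro-3-(trifluoromethyl)phenyl group held fixed, this one added chain carbon therefore leaves the number within the scatter, although a single pair cannot describe the position as a whole. No measurement shown here offers an explanation for this step or for the behaviour of either chain.

As far as these compounds go, it remains open whether a longer chain such as 4-(dimethylamino)butyl, or a morpholine or 4-methylpiperazine in place of the dimethylamino group, would move the number beyond the scatter. From the compounds shown here alone, it is also open whether the same lengthening would read alike with the 3-chloro-4-fluorophenyl group of compound 3 on the urea nitrogen.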